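Swapping the aryl group on the core of compound 1

The source may hold more compounds than are shown below. What is called first, only, known or untested is meant among the compounds shown, and "the series" means these compounds.

Compound 1, `COc1ccc(C(Nc2cc(C)ccn2)c2ccc3cccnc3c2O)cc1O`, has the lowest number among the three measured compounds. In an assay for inhibition of protein disulfide-isomerase (Homo sapiens), with a stated time of 1 h (on this read-out lower numbers stand for stronger inhibition and higher numbers for weaker inhibition), compound 1 gives 150 nM. Compound 3, `Oc1c(C(c2ccc(F)cc2)N2CCCCC2)ccc2cnccc12`, gives 610 nM, and compound 2, `COc1cccc(C(Nc2ccccn2)c2ccc3cccnc3c2O)c1`, gives 2860 nM; both of those numbers lie beyond the scatter above the number of compound 1.

Compound 4, `Cc1ccnc(NC(c2ccccc2C)c2ccc3cccnc3c2O)c1`, has not yet been measured. It differs from compound 1 in one place: 2-methylphenyl in place of 3-hydroxy-4-methoxyphenyl on a saturated chain carbon bound to an aromatic carbon and a nitrogen on an aromatic ring. For the measured compounds named here, no measured pair of compounds shows this exact change. Compound 2 carries an aryl group without the hydroxyl and also a different aminopyridine, so its value cannot stand for the size of this step; it only shows that a related compound with a plainer aryl group sits at a much higher number. The step from compound 1 to compound 4 is therefore expected to run toward weaker inhibition, beyond the scatter, at a 6.7-fold higher number from compound 1 to compound 4 (0.82 log units; beyond the scatter). For compound 4 the estimate in this assay is 1000 nM, expected to fall between 300 nM and 4000 nM.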

Compound 4, half-maximal inhibitory concentration: > 40000 nM
Compound 4: a limit, no number (the forecaster's own chance of this, stated with the estimate: 5%); middle value at least 40-fold (1.60 log units) away from the limit.
By their numbers in this assay, from the lowest: compound 1; then compound 3; then compound 2. At a limit, above all of these: compound 4.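

In this assay compound 4 gives > 40000 nM, which is a limit of the assay and not a number. Putting 2-methylphenyl in place of 3-hydroxy-4-methoxyphenyl on a saturated chain carbon bound to an aromatic carbon and a nitrogen on an aromatic ring brings an at least 260-fold higher number from compound 1 to compound 4 (2.42 log units; beyond the scatter), the first direct sign, from a pair differing in one place, that the read-out depends strongly on the aryl group here. The full size of this step stays unknown because compound 4 stands at a limit: the limit of > 40000 nM in this assay, at which 1 of the 4 values shown sits.

The change replaces the whole aryl group at once, so the compounds shown cannot separate the part played by the hydroxyl, the methoxy or the methyl. They also leave open how a phenyl group carrying an amine or a carboxylic acid would read at this place.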